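The compounds below may be only part of what the source reports. "The series", "measured", "known", "first", "only" and "open" are said of these compounds alone.

Compound 1 `C[C@H](C#Cc1cccc(C(=O)NCc2ccccc2C(F)(F)F)c1)N(O)C(N)=O` gives 600 nM in an assay for inhibition of Polyunsaturated fatty acid 5-lipoxygenase (Homo sapiens), read by HPLC, with stated times of 15 min and 10 min (on this read-out lower numbers stand for stronger inhibition and higher numbers for weaker inhibition), the lower of the two numbers recorded so far. Compound 2 `C[C@H](C#Cc1cccc(C(=O)NCCC(c2ccccc2)c2ccc(S(N)(=O)=O)cc2)c1)N(O)C(N)=O` gives 1000 nM in this assay, a difference that lies within the scatter, so no order between the two is claimed. Compound 3 `CC(C)CC(C#Cc1cccc(C(=O)NCc2ccccc2C(F)(F)F)c1)N(O)C(N)=O` has not been measured; it differs from compound 1 by 1-(carbamoyl(hydroxy)amino)-3-methylbutyl in place of 1-(carbamoyl(hydroxy)amino)ethyl on a triple-bonded carbon. Within the data shown here, no step between measured compounds is available to anchor this change, so the expectation rests on compound 1 alone. A step of a 2.0-fold higher number from compound 1 to compound 3 (0.30 log units; within the scatter) is expected, toward a weaker result, but of a size close to the scatter. Compound 3 is estimated at 1200 nM, in the range 400 nM to 3500 nM.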

Compound 3, half-maximal inhibitory concentration: 600 nM
Compound 3: the middle estimate sits 2.0-fold (0.30 log units) above what was measured; the measured number falls inside the stated range.
By their numbers in this assay, from the lowest: compounds 1, 3 and 2 (each within the scatter of the next).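

In this assay, among these compounds, the place on a triple-bonded carbon tolerates 1-(carbamoyl(hydroxy)amino)-3-methylbutyl in place of 1-(carbamoyl(hydroxy)amino)ethyl, with no change at the digits printed from compound 1 to compound 3 (within the scatter) as the first one-place comparison. The step covers two differences together: 10 heavy atoms replace 7, and the defined stereocentre of the leaving group has no counterpart in the entering group. (Nothing available bears on why the number holds)

Open, from the compounds shown here alone, are the separate readings of the two mirror forms of compound 3 and the effect of a longer chain or a phenyl ring at this place. Going by these compounds, whether the same change holds on compound 2 also remains open.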